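The source may report more compounds than this note shows. Statements on the series, on what has been measured and on what is new or still open speak of the compounds shown alone.

Working notes on the series. Going by the values given here, compound 1 `COc1ccc(C(=O)/C=C/c2cc(-c3cc(OC)c(OC)c(OC)c3)n[nH]2)cc1OC` is the reference point; in a functional assay on NCI/ADR-RES cells (Homo sapiens) for cytotoxicity, read by sulforhodamine B assay, with a stated time of 48 h, tested at 100 uM (a higher number here means a weaker effect of the compound at the concentration tested, a lower number a stronger effect), compound 1 gives -40%, the lowest of the two numbers so far. Among the compounds with values here, compound 2 `COc1cc(-c2cc(/C=C/C(=O)c3ccc(F)c(F)c3)[nH]n2)cc(OC)c1OC` gives -5% in this assay, and the only measured step, a number 35 percentage points higher from compound 1 to compound 2 (beyond the scatter), follows the exchange of 3,4-difluorophenyl for 3,4-dimethoxyphenyl on the carbonyl carbon. Compound 3 `COc1cc(C(=O)/C=C/c2cc(-c3cc(OC)c(OC)c(OC)c3)n[nH]2)cc(OC)c1OC` is not yet measured. It differs from compound 1 by methoxy in place of hydrogen on an aromatic carbon, the new group sitting ortho to a methoxy group, meta to a large group and meta to a methoxy group. Within the data shown here, no measured step matches this change: the step from compound 1 to compound 2 alters the same ring but in a different way, so it does not transfer. With nothing to say otherwise, the expected step from compound 1 to compound 3 is a number 5 percentage points lower from compound 1 to compound 3 (within the scatter), within the scatter. Compound 3 is therefore estimated at -45% in this assay, with a range from -75% to -15%.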

Compound 3, a percentage reported as activity, at one concentration (the size of the read-out at that concentration, not a potency): -24%
Beside the measured number, compound 3's estimate is 21 percentage points below it, and the stated range covers the measured number.
By their numbers in this assay, from the lowest: compound 1; then compound 3; then compound 2.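

In this assay, methoxy in place of hydrogen on this aromatic carbon gives a number 16 percentage points higher from compound 1 to compound 3 (beyond the scatter), so this position, ortho to a methoxy group, is sensitive to substitution. The earlier step exchanged the ring's substituents outright, whereas this one keeps the existing methoxy groups and adds a single group, and the number still moves toward a weaker effect at the concentration tested. Nothing at hand accounts for this shift.

Open, going by these compounds, is whether a fluorine or an amine on this carbon would move the number in the same direction, or whether the shift is particular to methoxy. Also open, on these data alone, is whether a longer chain, such as ethoxy, on this carbon would give a step of a different size.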